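The compounds below may be only part of what the source reports. "The series", "measured", "known", "first", "only" and "open" are said of these compounds alone.

Working notes on the series in a functional assay on HCC 2998 cells (Homo sapiens) for inhibition, read by sulforhodamine B assay, with a stated time of 48 h; a lower number here means a stronger inhibitor of growth, a higher number a weaker inhibitor of growth.

Three compounds carry a number. Compound 1 `COc1cc(-c2cc(/C=C/C(=O)c3ccc(N)cc3)[nH]n2)cc(OC)c1OC` gives 3630 nM, the lowest of the three. Compound 2 `COc1ccc(-c2cc(/C=C/C(=O)c3ccc(OC)c(OC)c3)[nH]n2)cc1` gives 3970 nM, which sits within the scatter of compound 1, so no order between the two is claimed. Within the data shown here, compound 3 `COc1cc(-c2cc(/C=C/C(=O)c3ccc(Cl)c(Cl)c3)[nH]n2)cc(OC)c1OC` gives 31400 nM; the one measured step in the set, an 8.7-fold higher number from compound 1 to compound 3 (0.94 log units; beyond the scatter), is a modest loss of growth inhibition. That step sits on the carbonyl side of the shared core.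

Compound 4 `COc1ccc(-c2cc(/C=C/C(=O)c3ccc(N)cc3)[nH]n2)cc1OC` differs from compound 1 on the other side of the core: hydrogen in place of methoxy on an aromatic carbon. Among the measured compounds shown here, no measured step in the set touches this position, so the only guide is that the change is small and removes a single group from the aryl ring that is kept in compound 1 and compound 3 alike. The step is therefore expected to be small, and a change beyond the scatter is not anticipated, with a 1.4-fold higher number from compound 1 to compound 4 (0.14 log units; within the scatter) as the expected movement. Compound 4 is estimated at 5000 nM, within a range of 1800 nM to 14000 nM.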

Compound 4, concentration for total growth inhibition: 3830 nM
The estimate for compound 4 lay 1.3-fold (0.12 log units) above the measured number; the range from low to high includes it.
By their numbers in this assay, from the lowest: compounds 1, 4 and 2 (each within the scatter of the next); then compound 3.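

In this assay, among these compounds, hydrogen in place of methoxy on an aromatic carbon gives a 1.1-fold higher number from compound 1 to compound 4 (0.02 log units; within the scatter) and is the first measured step on this side of the shared core, so the two compounds cannot be told apart. With 4-aminophenyl on the carbonyl, the methoxy group at this place, ortho to a methoxy group and meta to a large group, is therefore not required for a number of this size. Nothing on hand gives a reason for this result.

As far as these compounds go, this position is read through one pair only, so whether the same holds with the 3,4-dichlorophenyl group of compound 3 remains open. Also open, from the compounds shown here alone, is how this assay would read an ethoxy group, a fluorine atom or an amine at this place.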